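The source may hold more compounds than are shown below. What is called first, only, known or untested is meant among the compounds shown, and "the series" means these compounds.

Measured so far in the series:

- compound 1 `COc1ccccc1C1C(C#N)=C(N)N(c2ccc(S(N)(=O)=O)cc2)C2=C1C(=O)CCC2` gives 0% in a functional assay on Ehrlich cells (Mus musculus) for antiproliferative activity, read by trypan blue exclusion, with a stated time of 2 h, tested at 10 ug/mL; a higher number here means a stronger effect of the compound at the concentration tested, a lower number a weaker effect
- compound 2 `N#CC1=C(N)N(c2ccc(S(N)(=O)=O)cc2)C2=C(C(=O)CCC2)C1c1ccc([N+](=O)[O-])cc1` gives 85% in this assay
- compound 3 `Cc1ccoc1C1C(C#N)=C(N)N(c2ccc(S(N)(=O)=O)cc2)C2=C1C(=O)CCC2` gives 2% in this assay

Compound 2 stands highest of the three numbers: the rise is a number 85 percentage points higher from compound 1 to compound 2 (beyond the scatter), and the fall on to the next compound is a number 83 percentage points lower from compound 2 to compound 3 (beyond the scatter). Both steps are beyond the scatter, so the reading for compound 2 is set clearly apart from the other two, which lie within the scatter of each other (a number 2 percentage points higher from compound 1 to compound 3 (within the scatter)).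

The next compound, compound 4 `N#CC1=C(N)N(c2ccc(S(N)(=O)=O)cc2)C2=C(C(=O)CCC2)C1c1cccs1`, is reached from compound 2 by one change: thiophen-2-yl in place of 4-nitrophenyl on a saturated ring carbon.

For the measured compounds named here, two measured steps bear on this. Going by the values given here, the step of a number 85 percentage points higher from compound 1 to compound 2 (beyond the scatter) shows that the 4-nitrophenyl group goes with the one high reading, and the step of a number 83 percentage points lower from compound 2 to compound 3 (beyond the scatter) shows that exchanging it for a five-membered aromatic ring with one hetero atom removes almost all of the effect. Thiophen-2-yl is likewise a five-membered aromatic ring with one hetero atom, so a large fall is expected in this assay, of a size comparable to the step to compound 3.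

For compound 4 the expected step is a number 73 percentage points lower from compound 2 to compound 4 (beyond the scatter), giving an estimated value of 12%, within a range from 0% to 45%.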

Compound 4, a percentage reported as activity, at one concentration (the size of the read-out at that concentration, not a potency): 70%
Estimate against measurement, compound 4: 58 percentage points below; measured number outside the range, above it.
By their numbers in this assay, from the lowest: compounds 1 and 3 (each within the scatter of the next); then compound 4; then compound 2.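

In this assay, for the compounds shown here, the thiophen-2-yl group keeps most of the reading, with a number 15 percentage points lower from compound 2 to compound 4 (beyond the scatter) as a modest step, so the 4-nitrophenyl group is not the only group on this saturated ring carbon that goes with a high reading. A five-membered aromatic ring with one hetero atom does not by itself remove the effect: a number 68 percentage points higher from compound 3 to compound 4 (beyond the scatter) separates two groups of that ring type, and a number 70 percentage points higher from compound 1 to compound 4 (beyond the scatter) shows thiophen-2-yl also standing well clear of 2-methoxyphenyl. Ring size therefore does not sort the series at this position, since each ring size now appears at both ends, with compound 2 and compound 3 going against any rule that favours the five-membered or the six-membered ring alone, and compound 4 and compound 1 going against it likewise.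

Still open, as far as these compounds go, is whether the low readings follow the ring or the methoxy and methyl groups it carries, a question that unsubstituted phenyl, unsubstituted furan-2-yl and 3-methylthiophen-2-yl would help to settle at this same carbon. No measurement at hand accounts for the gap between these groups.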